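From Butyl to Oxan-4-yl on the Aryl Ether

A few compounds are considered here, and "the series" means these few. Any claim that something is new, unique, unknown or untested is made for them only; others in the source may bear on it.

Two aryl ethers have been measured. Compound 1 `O=C1OCCN1C(=O)c1ccc(OC2CCCCC2)cc1` carries a cyclohexyl group on the oxygen on the aromatic ring, and in an assay on HEK293 cells for inhibition of N-acylethanolamine-hydrolyzing acid amidase (Rattus norvegicus), read by LC-MS, with a stated time of 30 min (a higher number here means a weaker inhibitor, a lower number a stronger inhibitor), compound 1 gives 92 nM. Compound 2 `CCCCOc1ccc(C(=O)N2CCOC2=O)cc1` carries a butyl group in that place, and in this assay compound 2 gives 1340 nM. Among the measured compounds shown here, the only measured step is a 15-fold higher number from compound 1 to compound 2 (1.16 log units; beyond the scatter). For the measured compounds named here, compound 2 therefore stands at the higher of the two numbers, with compound 1 as its only neighbour and well separated from it.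

Compound 3 `O=C1OCCN1C(=O)c1ccc(OC2CCOCC2)cc1` is not yet measured. It differs from compound 2 by oxan-4-yl in place of butyl on an oxygen on an aromatic ring. Going by the values given here, the one measured step that bears on this change, a 15-fold higher number from compound 1 to compound 2 (1.16 log units; beyond the scatter), shows that trading a six-membered ring for a butyl chain in this place moved the number a long way; the oxan-4-yl group of compound 3 brings back a six-membered ring, now with one oxygen in it. A step back towards the number of compound 1 is therefore expected in this assay. Among the compounds with values here, how much of that distance is recovered the data do not tell: no measured pair compares cyclohexyl with oxan-4-yl. In this assay compound 3 is expected near 300 nM, within a range from 100 nM to 900 nM. This corresponds to an expected step of a 4.5-fold lower number from compound 2 to compound 3 (0.65 log units; beyond the scatter).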

Compound 3, half-maximal inhibitory concentration: 330 nM
Estimate against measurement, compound 3: 1.1-fold (0.04 log units) below; low and high end bracket the measured number.
By their numbers in this assay, from the lowest: compound 1; then compound 3; then compound 2.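

Read with the earlier compounds, this assay now shows a second six-membered ring on this oxygen on an aromatic ring giving a lower number than the butyl group, with a 4.1-fold lower number from compound 2 to compound 3 (0.61 log units; beyond the scatter). Among the compounds shown here, the ring does not fully account for the position of compound 1, however, as the first comparison of the two rings on this oxygen gives a 3.6-fold higher number from compound 1 to compound 3 (0.55 log units; beyond the scatter), so replacing cyclohexyl with oxan-4-yl, which has one oxygen in its ring, is itself a change beyond the scatter, and compound 3 falls between compound 1 and compound 2. No accompanying measurement accounts for either of these steps, so the numbers record the size of each change and give no explanation of it.

The compounds shown leave open whether the lower numbers follow the ring itself or would also appear with an open-chain group such as hexyl or a branched group such as isopropyl. They also leave open how other ring groups on this oxygen would compare with cyclohexyl and oxan-4-yl, for example cyclopentyl, phenyl, or a piperidin-4-yl ring carrying an amine.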